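The source may hold more compounds than are shown below. What is called first, only, known or untested is meant among the compounds shown, and "the series" means these compounds.

Compounds 1 and 2 share one core. Compound 1 `CCOC(=O)C1=C(Nc2ccccc2)S/C(=C\c2ccc(Br)c(O)c2)C1=O` gives 13.6% in a functional assay on A549 cells (Homo sapiens) for inhibition, read by MTT assay, with a stated time of 72 h, tested at 10 uM; on this read-out lower numbers stand for less inhibition and higher numbers for more inhibition at the one concentration tested (going by the name of the read-out). Compound 2 `CCOC(=O)C1=C(Nc2ccccc2)S/C(=C\c2ccc[nH]2)C1=O` gives 23.5% in this assay, and the only measured step, a number 9.9 percentage points higher from compound 1 to compound 2 (within the scatter), is the sole comparison available; on the numbers shown, compound 2 stands within the scatter of compound 1, so the two values cannot be separated. Compound 3 `CCOC(=O)C1=C(Nc2ccc(Br)cc2)S/C(=C\c2ccc[nH]2)C1=O` has not yet been measured. It differs from compound 2 by bromo in place of hydrogen on an aromatic carbon. Going by the values given here, no measured step touches this part of the molecule: the single known step, a number 9.9 percentage points higher from compound 1 to compound 2 (within the scatter), concerns the group on the double-bonded chain carbon, not the anilino portion, and even that change stayed within the scatter. With nothing bearing on the anilino portion, no movement beyond the scatter is expected in this assay, and the expected step is a number 1.5 percentage points higher from compound 2 to compound 3 (within the scatter). Compound 3 is therefore estimated at 25% in this assay, with a range from 10% to 45%, an estimate that rests only on the value of compound 2, 23.5%.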

Compound 3, a percentage reported as inhibition, at one concentration (the size of the read-out at that concentration, not a potency): < 10%
Compound 3: a limit, no number; the forecaster's own chance of this, stated with the estimate: 0%; at least 15 percentage points between middle value and limit.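

The anilino portion, which no earlier step had touched, turns out to matter in this assay: the change from phenyl to 4-bromophenyl, with the bromo para to a large group, gives a number at least 13.5 percentage points lower from compound 2 to compound 3 (beyond the scatter), and this is the only step shown that lies beyond the scatter. In this assay compound 3 gives < 10%, which is a limit of the assay and not a number. The step is therefore known only as a bound and its full size stays undefined, so this position is shown to be sensitive to the change without a measure of how sensitive it is: the limit of < 10% in this assay, at which 1 of the 3 values shown sits.

The compounds shown leave open whether this loss belongs to bromo itself or to any group at this place on the aromatic ring, since fluoro, methoxy, an amine or a carboxylic acid at the same carbon would separate those readings. They also leave open whether 4-bromophenyl on the nitrogen has the same effect when the 4-bromo-3-hydroxyphenyl group of compound 1 replaces the 1H-pyrrol-2-yl group of compound 2.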